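This account rests on a few compounds, and the source may have more. Where it says the series, first, only, none or still open, it means among the compounds named here.

Measured so far in a functional assay on PANC-1 cells (Homo sapiens) for inhibition, read by MTT assay, with a stated time of 48 h; a lower number here means a stronger inhibitor, a higher number a weaker inhibitor:
compound 1 `CC(=O)c1ccc(NC(=O)CSc2nc3c([nH]2)c(=O)n(C)c(=O)n3C)cc1` gives 5100 nM;
compound 2 `CC(=O)c1ccc(NC(=O)CSc2nc3[nH]c(=O)n(C)c(=O)c3[nH]2)cc1` gives 5900 nM;
compound 3 `Cn1c(=O)c2[nH]c(SCC(=O)c3ccccc3)nc2n(C)c1=O` gives 4900 nM.

Compound 1 and compound 2 differ in one place, (hydrogen in place of methyl on an aromatic nitrogen), and this change produced a 1.2-fold higher number from compound 1 to compound 2 (0.06 log units; within the scatter). Compound 3 carries a different side group on its core; the difference between the core of compound 1 and the core of compound 3 is not broken down here. The three values sit close together in this assay, and no order among them can be read.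

Compound 4 `Cn1c(=O)[nH]c2nc(SCC(=O)c3ccccc3)[nH]c2c1=O` is not yet measured. It differs from compound 3 by hydrogen in place of methyl on an aromatic nitrogen, the same change as that from compound 1 to compound 2, at the same place. Within the data shown here, the one earlier occurrence, a 1.2-fold higher number from compound 1 to compound 2 (0.06 log units; within the scatter), is the only guide. In this assay compound 4 is therefore expected to give 5500 nM, meaning a step of a 1.1-fold higher number from compound 3 to compound 4 (0.05 log units; within the scatter), likely within the scatter, as the earlier one was.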

Compound 4, half-maximal inhibitory concentration: 9400 nM
For compound 4 the middle estimate is 1.7-fold (0.23 log units) below the measured one; low and high end bracket the measured number.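

In this assay, hydrogen in place of methyl on an aromatic nitrogen gives a 1.9-fold higher number from compound 3 to compound 4 (0.28 log units; within the scatter) in the second pair carrying this change. This rests on two pairs only and shows neither that the step would keep its size on other cores nor that the methyl group can be dropped without consequence elsewhere in the series. Within these two pairs, the change carries from one core to the other with no difference that can be read: the same change on two cores in this assay, a 1.2-fold higher number (0.06 log units; within the scatter) from compound 1 to compound 2 and a 1.9-fold higher number (0.28 log units; within the scatter) from compound 3 to compound 4, 1.7-fold (0.22 log units) apart, within the scatter of two such steps

The compounds shown leave open whether a longer chain on that aromatic nitrogen would move the number beyond the scatter. From the compounds shown here alone, it is also open whether an amine or a carboxylic acid on the phenyl ring of the side group would do so.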